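The source may hold more compounds than are shown below. What is called first, only, known or untested is meant among the compounds shown, and "the series" means these compounds.

Of the compounds shown here, three have been measured so far in a functional assay on HepG2 cells (Homo sapiens) for antiproliferative activity, read by MTT assay, with a stated time of 24 h; on this read-out lower numbers stand for stronger inhibition and higher numbers for weaker inhibition.

Compound 1, `COc1cccc(/C=C/C(=O)c2ccc(OC)c3c2OC(C)(C)C=C3)c1`, gives > 10000 nM, a limit of the assay and not a number.
Compound 2, `COc1ccc(C(=O)/C=C/c2cc(OC)c(OC)c(OC)c2)c2c1C=CC(C)(C)O2`, gives > 10000 nM, likewise a limit of the assay.
Compound 3, `COc1ccc(C(=O)/C=C/c2cccc(O)c2)c2c1C=CC(C)(C)O2`, gives > 10000 nM, again a limit of the assay.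

Compound 3 arises from compound 1 by hydrogen in place of methyl on an oxygen on an aromatic ring. The step between them, a step that the two limits leave unreadable from compound 1 to compound 3, has no readable size, since every value shown sits at the limit of > 10000 nM in this assay, at which 3 of the 3 values shown sit. Compound 2 differs from compound 1 in more than one place, and the difference between the two cores is not broken down here.

Compound 4, `COc1cc(/C=C/C(=O)c2ccc(OC)c3c2OC(C)(C)C=C3)cc(OC)c1O`, is not yet measured. It arises from compound 2 by hydrogen in place of methyl on an oxygen on an aromatic ring, the same change as that from compound 1 to compound 3, made at a place described in the same words. With the earlier step that the two limits leave unreadable from compound 1 to compound 3 unreadable and all three values resting at the limit of > 10000 nM in this assay, at which 3 of the 3 values shown sit, the expected step is a step that the limit leaves unreadable from compound 2 to compound 4. Compound 4 is therefore estimated at 15000 nM, most likely again a limit, with a range from 5000 nM to 60000 nM.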

Compound 4, half-maximal inhibitory concentration: > 10000 nM
Compound 4 ended at the assay's limit; the forecaster's own chance of this, stated with the estimate: 75%; the middle value lies beyond the limit too.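

Compound 4 rests at a limit of the assay, as compound 2 does, so no size can be read for the step between them in this assay: the limit of > 10000 nM in this assay, at which 4 of the 4 values shown sit.

The compounds shown leave open whether methoxy to hydroxy changes anything in this assay, and which structure would give a value below the limit.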